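Fluorophenyl swap on the arylidene arm of compound 3

This account rests on a few compounds, and the source may have more. Where it says the series, first, only, none or still open, it means among the compounds named here.

Compound 3 `C=CCn1c(=O)/c(=C\c2cccc(Br)c2)[nH]c(=O)/c1=C\c1ccccc1OC` gives the lowest number of the three measured in a functional assay on HeLa cells (Homo sapiens) for cytotoxicity, read by CCK-8 assay, with a stated time of 72 h (on this read-out lower numbers stand for stronger inhibition and higher numbers for weaker inhibition), at 5400 nM. Compound 1 `C=CCn1c(=O)/c(=C\c2cccc(F)c2)[nH]c(=O)/c1=C\c1ccccc1OC` gives 9100 nM, and the step of a 1.7-fold lower number from compound 1 to compound 3 (0.23 log units; within the scatter) is within the scatter. Compound 2 `C=CCn1c(=O)/c(=C\c2cc(Br)ccc2F)[nH]c(=O)/c1=C\c1ccccc1OC` gives 34600 nM, and the steps of a 3.8-fold higher number from compound 1 to compound 2 (0.58 log units; beyond the scatter) and a 6.4-fold lower number from compound 2 to compound 3 (0.81 log units; beyond the scatter) are both beyond it. Compound 4 `C=CCn1c(=O)/c(=C\c2ccccc2F)[nH]c(=O)/c1=C\c1ccccc1OC` differs from compound 3 by 2-fluorophenyl in place of 3-bromophenyl on a double-bonded chain carbon bound to an aromatic carbon. The step from compound 2 to compound 3 bears most directly, as it removes the fluoro group; here that group enters while bromo leaves. A modest rise in this assay is therefore expected, smaller than the step from compound 2. Compound 4 is estimated at 15000 nM, range 5000 nM to 45000 nM, meaning an expected step of a 2.8-fold higher number from compound 3 to compound 4 (0.44 log units; beyond the scatter).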

Compound 4, half-maximal inhibitory concentration: 45000 nM
Compound 4: the middle estimate sits 3.0-fold (0.48 log units) below what was measured; measured number inside the range.
By their numbers in this assay, from the lowest: compounds 3 and 1 (each within the scatter of the next); then compounds 2 and 4 (each within the scatter of the next).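

In this assay, the 2-fluorophenyl arm gives a clearly higher number than either 3-substituted arm, 3-bromophenyl (an 8.3-fold higher number from compound 3 to compound 4 (0.92 log units; beyond the scatter)) and 3-fluorophenyl (a 4.9-fold higher number from compound 1 to compound 4 (0.69 log units; beyond the scatter)), both beyond the scatter. Removing bromo from the 5-bromo-2-fluorophenyl arm changes little (a 1.3-fold higher number from compound 2 to compound 4 (0.11 log units; within the scatter)), within the scatter, so among these four compounds, compound 2 and compound 4, the two carrying fluoro on a 2-fluorophenyl arm, both read high. No measurement offered here accounts for this. Going by these compounds, whether an unsubstituted phenyl arm would read nearer compound 3 or compound 4 remains open, as does the effect of an amine or a carboxylic acid on this arm.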